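Hydroxy on the benzimidazole core and a trifluoromethoxy-to-hydroxy swap

This account rests on a few compounds, and the source may have more. Where it says the series, first, only, none or still open, it means among the compounds named here.

Compound 1 `FC(F)(F)Oc1ccc(-c2ccc(-c3ccc(-c4nc5ccccc5[nH]4)cc3)cc2)cc1`: 100000 nM
Compound 2 `Oc1ccc(-c2ccc(-c3ccc(-c4nc5ccccc5[nH]4)cc3)cc2)cc1`: 100000 nM
Compound 3 `Oc1cccc2[nH]c(-c3ccc(-c4ccc(-c5ccc(OC(F)(F)F)cc5)cc4)cc3)nc12`: 3800 nM

In a functional assay on ZR-75-1 cells (Homo sapiens) for inhibition, read by sulforhodamine B assay (a higher number here means a weaker inhibitor of growth, a lower number a stronger inhibitor of growth), compound 1 gives 100000 nM and compound 2 gives 100000 nM. The change between them is hydrogen in place of trifluoromethyl on an oxygen on an aromatic ring, and the step is no change at the digits printed from compound 1 to compound 2 (within the scatter). Compound 3 carries a different core: relative to compound 1 the difference is hydroxy in place of hydrogen on an aromatic carbon, and this brings a 26-fold lower number from compound 1 to compound 3 (1.42 log units; beyond the scatter), so compound 3 gives 3800 nM in this assay.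

Compound 4 `Oc1ccc(-c2ccc(-c3ccc(-c4nc5c(O)cccc5[nH]4)cc3)cc2)cc1` has not yet been measured. It stands to compound 3 as compound 2 stands to compound 1: the change is hydrogen in place of trifluoromethyl on an oxygen on an aromatic ring, the same change as before, on the same kind of place. Going by the values given here, only one earlier example of this change exists, and it left the number unchanged within the scatter, so compound 4 is expected to sit close to compound 3 in this assay, with a step of about a 1.3-fold higher number from compound 3 to compound 4 (0.12 log units; within the scatter). The estimate for compound 4 is therefore 5000 nM, with a range from 1500 nM to 20000 nM.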

Compound 4, concentration for 50% growth inhibition: 2650 nM
Beside the measured number, compound 4's estimate is 1.9-fold (0.28 log units) above it; the measured number falls inside the stated range.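

In this assay, replacing trifluoromethoxy with hydroxy makes no real difference on the hydroxy-bearing core, with a 1.4-fold lower number from compound 3 to compound 4 (0.16 log units; within the scatter), and this matches what the same swap does on the core of compound 1: the same change on two cores in this assay, no change at the digits printed (within the scatter) from compound 1 to compound 2 and a 1.4-fold lower number (0.16 log units; within the scatter) from compound 3 to compound 4, 1.4-fold (0.16 log units) apart, within the scatter of two such steps
Adding the hydroxy to the core also carries over, with a 38-fold lower number from compound 2 to compound 4 (1.58 log units; beyond the scatter), a large step of much the same size as on the other pair: the same change on two cores in this assay, a 26-fold lower number (1.42 log units; beyond the scatter) from compound 1 to compound 3 and a 38-fold lower number (1.58 log units; beyond the scatter) from compound 2 to compound 4, 1.4-fold (0.16 log units) apart, within the scatter of two such steps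
So each change behaves alike in both settings here, but this rests on just one pair of cores and one place for each change, so it shows neither that the pattern extends to other cores nor why the hydroxy on the core has such a large effect.

The compounds shown leave open whether an amine or a methoxy group could stand in for the hydroxy on the core. They also leave open what a carboxylic acid or a longer chain would do in place of the trifluoromethyl on the oxygen.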